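Working notes on the step from compound 2 to compound 3

The source may hold more compounds than are shown below. What is called first, only, known or untested is meant among the compounds shown, and "the series" means these compounds.

Compound 2 `NC(=O)c1c(NC(=O)c2ccccc2Cl)sc2c1CCN(C(=S)Nc1ccccc1C(F)(F)F)C2` gives 10600 nM in a functional assay on HL-60 cells (Homo sapiens) for antiproliferative activity, with a stated time of 24 h (a lower number here means a stronger inhibitor, a higher number a weaker inhibitor), the higher of the two numbers to hand, while compound 1 `N#Cc1ccccc1CN1CCc2c(sc(NC(=O)c3ccccc3Cl)c2C(N)=O)C1` gives 10400 nM in this assay, a gap within the scatter, so no order between the two is claimed. Compound 3 `COc1ccccc1NC(=S)N1CCc2c(sc(NC(=O)c3ccccc3Cl)c2C(N)=O)C1` differs from compound 2 by methoxy in place of trifluoromethyl on an aromatic carbon. For the measured compounds named here, no measured pair shows this change, and for compound 3 no step beyond the scatter is expected in this assay, in either direction: a 1.1-fold lower number from compound 2 to compound 3 (0.03 log units; within the scatter). Compound 3 is therefore estimated at 10000 nM, with a range from 4000 nM to 25000 nM.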

Compound 3, half-maximal inhibitory concentration: 40900 nM
The estimate for compound 3 lay 4.1-fold (0.61 log units) below the measured number, and the stated range ends below it.
By their numbers in this assay, from the lowest: compounds 1 and 2 (each within the scatter of the next); then compound 3.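

In this assay the substituent at this place on the aromatic ring does matter: methoxy in place of trifluoromethyl gives a 3.9-fold higher number from compound 2 to compound 3 (0.59 log units; beyond the scatter), whereas compound 1 and compound 2 showed no separation. The group on the amine nitrogen in the ring also shows a step beyond the scatter, with a 3.9-fold higher number from compound 1 to compound 3 (0.59 log units; beyond the scatter), so the nearness of compound 1 and compound 2 does not hold for every such group. No available data account for either step.

On these data alone, whether an amine or a carboxylic acid at this place would give a number nearer compound 2 or compound 3 remains open. Also open, as far as these compounds go, is whether a longer chain on the oxygen of methoxy would change the number further.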